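The source may report more compounds than this note shows. Statements on the series, on what has been measured and on what is new or still open speak of the compounds shown alone.

Compound 1 `COc1ccc(OC)c(-c2cc(-c3ccccc3)nn2-c2ccc(S(=O)(=O)NC(C)=O)cc2)c1` and compound 2 `COc1ccc(OC)c(-c2cc(-c3ccc(Cl)cc3)nn2-c2ccc(S(=O)(=O)NC(C)=O)cc2)c1` are built on one shared core. In a functional assay on cells (Cancer cell lines, Homo sapiens) for cytotoxicity, read by sulforhodamine B assay, with a stated time of 48 h (a lower number here means a stronger inhibitor of growth, a higher number a weaker inhibitor of growth), compound 1 gives 42600 nM, and compound 2 gives 50000 nM. The single difference between them is chloro in place of hydrogen on an aromatic carbon, and the step it made is a 1.2-fold higher number from compound 1 to compound 2 (0.07 log units; within the scatter), so the two values cannot be told apart. Compound 3 `NS(=O)(=O)c1ccc(-n2nc(-c3ccccc3)cc2-c2cc(O)ccc2O)cc1` rests on a different core; the difference between the two cores is not broken down here. In this assay compound 3 gives 100000 nM. Compound 4 `NS(=O)(=O)c1ccc(-n2nc(-c3ccc(Cl)cc3)cc2-c2cc(O)ccc2O)cc1` differs from compound 3 by chloro in place of hydrogen on an aromatic carbon; this is the same change that separates compound 1 from compound 2, made at a place described in the same words. From compound 3 to compound 4 the expected step is a 1.1-fold higher number from compound 3 to compound 4 (0.04 log units; within the scatter), which rests on the step from compound 1 to compound 2 being a 1.2-fold higher number from compound 1 to compound 2 (0.07 log units; within the scatter). The estimated value for compound 4 is therefore 110000 nM, with the expected range running from 50000 nM to 250000 nM.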

Compound 4, concentration for total growth inhibition: 35500 nM
Estimate against measurement, compound 4: 3.1-fold (0.49 log units) above; the whole stated range lies above it.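

In this assay, the change from phenyl to 4-chlorophenyl gives a 2.8-fold lower number from compound 3 to compound 4 (0.45 log units; beyond the scatter), so on this core the chloro compound is the stronger inhibitor of growth. Set beside the same change on the core of compound 1, the result did not carry over from one core to the other: the same change on two cores in this assay, a 1.2-fold higher number (0.07 log units; within the scatter) from compound 1 to compound 2 and a 2.8-fold lower number (0.45 log units; beyond the scatter) from compound 3 to compound 4, 3.3-fold (0.52 log units) apart, beyond the scatter of two such steps. This shows that, for these two cores, the step seen on one did not foretell the step on the other, but it does not show why, and with a single pair on each core it gives no rule for any other core or group.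

From the compounds shown here alone, all four compounds carry either hydrogen or chloro at this place, so it stays open whether a fluoro, a methoxy or an amino group would split between the two cores in the same way. Going by these compounds, the two cores also differ in more than one place, so it stays open which part of that difference goes with the split.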